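Lengthening the Ester in a Paw Edema Series

This account rests on a few compounds, and the source may have more. Where it says the series, first, only, none or still open, it means among the compounds named here.

Measured compounds:
compound 1 `N#CC1=C(NC(=O)c2ccccc2O)N(c2ccccc2)C(=O)N2CCCCC(N3CCCC3)C12`: 65.4%
compound 2 `COC(=O)C(=O)NC1=C(C#N)C2C(N3CCCC3)CCCCN2C(=O)N1c1ccccc1`: 88.3%

Among the measured compounds shown here, in a functional assay on the whole organism (strain albino) for inhibition, with Rattus norvegicus as the target, read by paw edema, with stated times of 1 h and 3 h, at a dose of 20 mmol/kg by the intraperitoneal route (a higher number here means a stronger effect of the compound at the dose given, a lower number a weaker effect), compound 2 gives the higher of the two numbers so far, and the only measured step, a number 22.9 percentage points higher from compound 1 to compound 2 (beyond the scatter), came from placing methoxycarbonyl in place of 2-hydroxyphenyl on a carbonyl carbon. Compound 3 `CCOC(=O)C(=O)NC1=C(C#N)C2C(N3CCCC3)CCCCN2C(=O)N1c1ccccc1` differs from compound 2 by methyl in place of hydrogen on a saturated chain carbon bound to an oxygen next to a carbonyl group. For the measured compounds named here, no measured step touches this place, so nothing here points to a shift, and the expected step is a number 3.3 percentage points lower from compound 2 to compound 3 (within the scatter), within the scatter. Compound 3 is therefore estimated at 85%, between 70% and 95%.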

Compound 3, a percentage reported as inhibition, in the whole organism at one dose (the size of the read-out at that dose, not a potency): 91.5%
Estimate against measurement, compound 3: 6.5 percentage points below; low and high end bracket the measured number.
By their numbers in this assay, from the lowest: compound 1; then compounds 2 and 3 (each within the scatter of the next).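

Methyl in place of hydrogen on a saturated chain carbon bound to an oxygen next to a carbonyl group gives a number 3.2 percentage points higher from compound 2 to compound 3 (within the scatter) in this assay, so going from methoxycarbonyl to ethoxycarbonyl brings no readable change. The ethoxycarbonyl compound also keeps the advantage over the 2-hydroxyphenyl compound, with a number 26.1 percentage points higher from compound 1 to compound 3 (beyond the scatter) as the step. Nothing measured here gives a reason for either step. On these data alone, whether a longer chain, such as butyl, on this oxygen would hold the effect stays open. So does the effect of a carboxylic acid in place of the ester.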